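A few compounds are considered here, and "the series" means these few. Any claim that something is new, unique, unknown or untested is made for them only; others in the source may bear on it.

In a functional assay on KARPAS-422 cells (Homo sapiens) for antiproliferative activity, read by resazurin assay, with a stated time of 72 h (on this read-out lower numbers stand for stronger inhibition and higher numbers for weaker inhibition), compound 1 `Cc1cc(C)c(CN2CCc3c(Cl)cc([C@H](CO)[C@H]4CCOC4)c(Cl)c3C2=O)c(=O)[nH]1` gives 15 nM. Among the compounds with values here, this is its only single number, and one further entry for it carries none. Sharing the core of compound 1, compound 2 `COC(c1cc(Cl)c2c(c1Cl)C(=O)N(Cc1c(C)cc(C)[nH]c1=O)CC2)C1CCN(C(=O)CO)CC1` has entries of 3140 nM; 21 nM (2 entries) in this assay, and these lie far apart. Compound 3 `Cc1cc(C)c(CN2CCc3c(Cl)cc(-c4c(C)noc4C)c(Cl)c3C2=O)c(=O)[nH]1` has not yet been measured. It differs from compound 1 by one change: a group of 7 heavy atoms (5 carbon, 1 nitrogen, 1 oxygen; one five-membered aromatic ring with 2 hetero atoms) in place of a group of 8 heavy atoms (6 carbon, 2 oxygen; one five-membered non-aromatic ring with 1 hetero atom), on an aromatic carbon. The new group stands on an aromatic carbon, ortho to a chloro group. Within the data shown here, no measured step tests this exchange, so the expectation is only a judgement, starting from compound 1 at 15 nM. A loss of inhibition beyond the usual scatter is expected, towards higher numbers in this assay. The expected change is a 13-fold higher number from compound 1 to compound 3 (1.12 log units; beyond the scatter). For compound 3 the estimated value is 200 nM, with an expected range of 40 nM to 1500 nM.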

Compound 3, half-maximal inhibitory concentration: 23 nM
Compound 3: the middle estimate sits 8.7-fold (0.94 log units) above what was measured; measured number below the stated range.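

In this assay, the exchange gives a 1.5-fold higher number from compound 1 to compound 3 (0.19 log units; within the scatter), so this aromatic carbon, ortho to a chloro group, tolerates a flat, five-membered aromatic ring in place of a five-membered non-aromatic one. The 3,5-dimethyl-1,2-oxazol-4-yl group has no hydrogen-bond donor and no defined stereocentre, so neither feature of the group that leaves is needed here to keep antiproliferative activity within the scatter of compound 1. Single numbers deserve some caution, since entries for one compound in this assay can differ widely: the several entries of compound 2 in this assay, 3140 nM; 21 nM (2 entries)

It remains open whether the two methyl groups on the new ring matter, since no compound shown lacks them. From the compounds shown here alone, it is also open whether a simple phenyl ring, a primary amine or a carboxylic acid at this position would hold the activity.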